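Swapping a Methylfuran for a Bromofuran

The source may report more compounds than this note shows. Statements on the series, on what has been measured and on what is new or still open speak of the compounds shown alone.

Going by the values given here, two related compounds have numbers so far in a functional assay on HT-29 cells (Homo sapiens) for cytotoxicity, read by MTT assay; on this read-out lower numbers stand for stronger inhibition and higher numbers for weaker inhibition. Here compound 1 `COc1ccc(OC)c(C(=O)/C=C/c2ccoc2)c1` gives 21300 nM, while compound 2 `COc1ccc(OC)c(C(=O)/C=C/c2ccc(C)o2)c1` gives 43000 nM, the higher and therefore weaker result of the pair. The next molecule, compound 3 `COc1ccc(OC)c(C(=O)/C=C/c2occc2Br)c1`, keeps the shared core and alters one group: 3-bromofuran-2-yl in place of 5-methylfuran-2-yl on a double-bonded chain carbon bound to a double-bonded chain carbon. Among the compounds with values here, only one measured step involves this same place, a 2.0-fold higher number from compound 1 to compound 2 (0.31 log units; beyond the scatter), a modest change between two furan groups. Within the data shown here, no measured compound carries bromine, so this single step is only a rough guide to size and says little about direction. Since compound 2 at 43000 nM holds the higher of just two numbers, a modest move towards lower numbers is expected. The expected change is a 1.5-fold lower number from compound 2 to compound 3 (0.19 log units; within the scatter). For compound 3, the estimated value is 28000 nM, within an expected range of 11000 nM to 70000 nM.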

Compound 3, half-maximal inhibitory concentration: 15200 nM
For compound 3 the middle estimate is 1.8-fold (0.27 log units) above the measured one; the measured number falls inside the stated range.
By their numbers in this assay, from the lowest: compounds 3 and 1 (each within the scatter of the next); then compound 2.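

Going by these compounds alone, at this place, on a double-bonded chain carbon bound to a double-bonded chain carbon, the earlier compounds showed only a rise in the number, but in this assay the bromofuran brings it back down, with a 2.8-fold lower number from compound 2 to compound 3 (0.45 log units; beyond the scatter) as 3-bromofuran-2-yl replaces 5-methylfuran-2-yl. Against the other furan the picture differs, with a 1.4-fold lower number from compound 1 to compound 3 (0.15 log units; within the scatter) when 3-bromofuran-2-yl replaces furan-3-yl, so bromine here brings no clear gain over that group. Compound 2 is now the weakest of the three, since its steps to both others lie beyond the scatter, and nothing available explains why the methylfuran stands apart.

From the compounds shown here alone, the bromofuran differs from each partner in more than one feature of the furan group, so the share of the bromine itself stays open. Going by these compounds, how a plain furan-2-yl group, a chlorine in place of the bromine, or an amine on the furan would behave also remains unknown.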